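The source may hold more compounds than are shown below. What is called first, only, known or untested is meant among the compounds shown, and "the series" means these compounds.

Of the compounds shown here, two have been measured in a physicochemical assay for solubility, using the shake flask method, with a stated time of 12 h; a lower number here means a less soluble compound, a higher number a more soluble compound. Compound 1 (`O=C(/C=C/c1cccc(O)c1)CC(=O)/C=C/c1cccc(O)c1O`) gives 8200 nM, and compound 2 (`O=C(/C=C/c1ccccc1O)CC(=O)/C=C/c1cc(O)ccc1O`) gives 4400 nM. Going by the values given here, these two numbers lie within the usual scatter of each other, so compound 2 cannot be separated from the only other compound measured. Compound 3 (`O=C(/C=C/c1cccc(O)c1)CC(=O)/C=C/c1cc(O)ccc1O`) has the same atoms as compound 2, joined differently. The change is 3-hydroxyphenyl in place of 2-hydroxyphenyl on a double-bonded chain carbon bound to a double-bonded chain carbon, with 3-hydroxyphenyl in place of 2-hydroxyphenyl on a double-bonded chain carbon bound to a double-bonded chain carbon. Among the compounds with values here, no measured pair differing in one place shows what such a change does. Within the data shown here, the only guide is the closeness of compound 1 at 8200 nM and compound 2 at 4400 nM, so no change beyond the scatter is expected in this assay. The estimated step is a 1.4-fold higher number from compound 2 to compound 3 (0.13 log units; within the scatter). Compound 3 is expected to give 6000 nM, with an estimated range of 2500 nM to 14000 nM.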

Compound 3, solubility: 5800 nM
The estimate for compound 3 lay 1.0-fold (0.01 log units) above the measured number; measured number inside the range.
By their numbers in this assay, from the lowest: compounds 2, 3 and 1 (each within the scatter of the next).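

In this assay the first pair differing in one place shows a 1.3-fold higher number from compound 2 to compound 3 (0.12 log units; within the scatter) and that step lies within the scatter, so 3-hydroxyphenyl in place of 2-hydroxyphenyl on a double-bonded chain carbon bound to a double-bonded chain carbon cannot be told from no change at this position. The second such pair, with 2,5-dihydroxyphenyl in place of 2,3-dihydroxyphenyl at that same place, shows a 1.4-fold lower number from compound 1 to compound 3 (0.15 log units; within the scatter) and also stays within the scatter, so neither swap separates these compounds in this assay as the earlier pair of numbers alone could not. No supporting data are at hand to explain these numbers.

All three compounds carry only hydroxyphenyl groups on the shared core, so these results leave open whether any change at this place can reach beyond the scatter. A methoxy group, an amine or a carboxylic acid on the aromatic ring might do so, and the compounds shown give no guide to any of them.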